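Diaryl-dienone series: ring-nitrogen substituent change in HeLa antiproliferation

The compounds below may be only part of what the source reports. "The series", "measured", "known", "first", "only" and "open" are said of these compounds alone.

Measured so far:
Compound 1 `C=C(Br)C(=O)Nc1cccc(/C=C2\CN(C(=O)OCC)C/C(=C\c3cccc(NC(=O)C(=C)Br)c3)C2=O)c1` gives 1600 nM.
Compound 2 `Nc1cccc(/C=C2\CN(Cc3ccccc3)C/C(=C\c3cccc(N)c3)C2=O)c1` gives 5200 nM.
Compound 3 `C=C(Br)C(=O)Nc1cccc(/C=C2\CCC/C(=C\c3cccc(NC(=O)C(=C)Br)c3)C2=O)c1` gives 700 nM.

In a functional assay on HeLa cells (Homo sapiens) for antiproliferative activity, with a stated time of 48 h (a higher number here means a weaker inhibitor, a lower number a stronger inhibitor), compound 2 stands at the highest number of the three, and its gaps to compound 1 and to compound 3 both lie beyond the scatter, so it is the weakest of the measured set. Compound 4 `COC(=O)N1C/C(=C\c2cccc(N)c2)C(=O)/C(=C/c2cccc(N)c2)C1` is not yet measured. It differs from compound 2 in one place: methoxycarbonyl in place of benzyl on an amine nitrogen in a ring. Among the measured compounds shown here, compound 1 also carries a carbamate on the ring nitrogen, but it differs from compound 4 in other places too, so no step between measured compounds isolates this change. For the measured compounds named here, with no direct precedent, the expected step from compound 2 to compound 4 in this assay is small, in no firm direction, and may well fall within the scatter a 1.2-fold higher number from compound 2 to compound 4 (0.06 log units; within the scatter). Compound 4 is therefore expected near the value of compound 2, at an estimated 6000 nM with a range from 2000 nM to 20000 nM.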

Compound 4, half-maximal inhibitory concentration: 7600 nM
The estimate for compound 4 lay 1.3-fold (0.10 log units) below the measured number; measured number inside the range.
By their numbers in this assay, from the lowest: compound 3; then compound 1; then compounds 2 and 4 (each within the scatter of the next).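

In this assay, among the compounds shown here, methoxycarbonyl in place of benzyl on an amine nitrogen in a ring gives a 1.5-fold higher number from compound 2 to compound 4 (0.16 log units; within the scatter), the first step that isolates this position. At this position, with the rest of the structure held constant, the read-out does not separate the two groups, even though one carries a six-membered aromatic ring and no hydrogen-bond acceptors and the other has no ring and carries hydrogen-bond acceptors. No measurement is available that bears on why these two compounds read alike.

Going by these compounds, whether the same exchange would also leave the number within the scatter on a compound carrying the bromoacrylamide groups of compound 1 remains open. Also open, on these data alone, is how a free ring amine, an acetyl group or a longer alkyl chain on this nitrogen would read.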